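The compounds below may be only part of what the source reports. "The series", "measured", "known", "first", "only" and "open" are said of these compounds alone.

Measured so far in a functional assay on L1210 cells (Mus musculus) for antiproliferative activity, read by cell counting, with a stated time of 2 days; a higher number here means a weaker inhibitor, a lower number a stronger inhibitor:
- compound 1 `COc1cc(C(=O)c2sc(Nc3ccc(F)cc3)nc2N)cc(OC)c1OC` gives 900 nM
- compound 2 `COc1ccc(C(=O)c2sc(Nc3ccc(Cl)cc3)nc2N)cc1` gives > 10000 nM (a limit of the assay, not a number)
- compound 3 `COc1ccccc1C(=O)c1sc(Nc2ccccc2)nc1N` gives 1100 nM

Among the measured compounds shown here, compound 1 holds one of only two true numbers in this set. Its nearest neighbour is compound 3 at 1100 nM and the two lie within the scatter of each other, so no order is read between them. Compound 2 is the one entry at a limit: the limit of > 10000 nM in this assay, at which 1 of the 3 values shown sits.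

Not yet measured is compound 4 `COc1ccc(Nc2nc(N)c(C(=O)c3cc(OC)c(OC)c(OC)c3)s2)cc1` which departs from compound 1 by methoxy in place of fluoro on an aromatic carbon in one place: methoxy in place of fluoro on an aromatic carbon, para to a large group, so that 4-fluorophenyl becomes 4-methoxyphenyl. For the measured compounds named here, no measured pair here isolates this change, so any size given for it is only an expectation. In this assay no shift beyond the scatter is expected, and the expected step is a 1.1-fold lower number from compound 1 to compound 4 (0.05 log units; within the scatter) in size. The expectation is anchored on compound 1 at 900 nM as the closest measured structure. Going by the values given here, the range stays wide, as no measured step is available to narrow it. For compound 4 the estimated value is 800 nM with an expected range from 200 nM to 4000 nM.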

Compound 4, half-maximal inhibitory concentration: 1500 nM
For compound 4 the middle estimate is 1.9-fold (0.27 log units) below the measured one, within the range that was stated.
By their numbers in this assay, from the lowest: compounds 1, 3 and 4 (each within the scatter of the next). At a limit, above all of these: compound 2.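

In this assay, among the compounds shown here, the one pair that differs in a single place gives a 1.7-fold higher number from compound 1 to compound 4 (0.22 log units; within the scatter), so 4-fluorophenyl and 4-methoxyphenyl are not told apart in this read-out. For the compounds shown here, this is the first direct reading at this position, on an aromatic carbon para to a large group: fluoro and methoxy are interchangeable here within the scatter, even though methoxy is the larger of the two by heavy atoms and adds a hydrogen-bond acceptor. The data shown give no measured basis for explaining this step.

Still open, from the compounds shown here alone, is whether the position tolerates groups of another kind, such as an amine, a carboxylic acid or a longer chain such as butoxy, since fluoro and methoxy alone do not show how far this tolerance extends. Compound 2 and compound 3 each differ from compound 1 in more than one place, so the contribution of the methoxy groups on the aromatic ring attached to the carbonyl cannot yet be read from any single-change pair.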